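Chloro to methoxy at the limit of the assay

The source may hold more compounds than are shown below. What is called first, only, known or untested is meant among the compounds shown, and "the series" means these compounds.

Compound 1 (`Cn1cc(C2=C(c3nn(CCCN4CCCCC4)c4ncccc34)C(=O)N(c3ccc(Cl)cc3)C2=O)c2ccccc21`) is read in a functional assay on ECa-109 cells (Homo sapiens) for antiproliferative activity, read by MTT assay, with a stated time of 48 h; a lower number here means a stronger inhibitor, a higher number a weaker inhibitor. There, compound 1 gives > 100000 nM, which is a limit and not a number. Compound 2 (`CN(C)CCCn1nc(C2=C(c3cn(C)c4ccccc34)C(=O)NC2=O)c2cccnc21`) gives > 100000 nM, also a limit. Compound 3 (`Cn1cc(C2=C(c3nn(CCCO)c4ncccc34)C(=O)NC2=O)c2ccccc21`) gives > 100000 nM, again a limit. Among the compounds with values here, the series so far therefore stands at the limit of > 100000 nM in this assay, at which 3 of the 3 values shown sit.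

Compound 4 (`COc1ccc(N2C(=O)C(c3cn(C)c4ccccc34)=C(c3nn(CCCN4CCCCC4)c4ncccc34)C2=O)cc1`) departs from compound 1 in a single place: methoxy in place of chloro on an aromatic carbon. This is methoxy in place of chloro on an aromatic carbon, 4-chlorophenyl to 4-methoxyphenyl.

Within the data shown here, the only measured step, a step that the two limits leave unreadable from compound 2 to compound 3, concerns a saturated chain and gives no size to carry over. Among the measured compounds shown here, no measured pair covers the chloro to methoxy change. With compound 1 at > 100000 nM, there is no number to start from, and no direction in this assay is supported. The expected result is therefore no step beyond the scatter, stated as a number no higher from compound 1 to compound 4 (the limit leaves the size open). Compound 4 is estimated at 100000 nM, with an expected range from 30000 nM to 200000 nM.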

Compound 4, half-maximal inhibitory concentration: 3340 nM
Estimate against measurement, compound 4: 30-fold (1.48 log units) above; the measured number lies below the stated range.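

In this assay, within the data shown here, methoxy in place of chloro on an aromatic carbon, para to a large group, gives an at least 29-fold lower number from compound 1 to compound 4 (1.47 log units; beyond the scatter), the first step with a readable size and the first sign that this position can move activity. Compound 1 stands at > 100000 nM, which is a limit, so the step has a floor but no full size. Compound 4 is the only compound shown with a number, and the other compounds remain at the limit: the limit of > 100000 nM in this assay, at which 3 of the 4 values shown sit.

On these data alone, this single pair cannot separate a gain from methoxy itself from a gain on losing chloro, and an ethoxy, a hydroxy or a dimethylamino group on the same carbon remains untested here. Also open, as far as these compounds go, is whether the change would act alike with the chains of compound 2 or compound 3.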